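The source may hold more compounds than are shown below. What is called first, only, known or untested is meant among the compounds shown, and "the series" means these compounds.

Compound 1 `Cc1cccc2c(=O)c(-c3nn[nH]n3)c[nH]c12` in a functional assay on the whole organism (strain Sprague-Dawley) for inhibition, with Rattus norvegicus as the target (on this read-out lower numbers stand for an effect already at smaller amounts and higher numbers for an effect only at larger amounts of compound), gives > 5 mg/kg, which is a limit of the assay rather than a number. Compound 2 `CSc1cccc2c(=O)c(-c3nn[nH]n3)c[nH]c12` in this assay gives 10 mg/kg, the only number shown for this series. The step that the limit leaves unreadable from compound 1 to compound 2 cannot be read because the limit of > 5 mg/kg in this assay, at which 1 of the 2 values shown sits, hides its size. Compound 3 `O=c1c(-c2nn[nH]n2)c[nH]c2c(C(F)(F)F)cccc12` differs from compound 2 by trifluoromethyl in place of methylsulfanyl on an aromatic carbon. No readable measured step bears on this change, so a step no larger than the scatter is expected. Compound 3 is therefore estimated at 10 mg/kg, between 3 mg/kg and 30 mg/kg, meaning an expected step of no change at the digits printed from compound 2 to compound 3 (within the scatter).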

Compound 3, minimum effective dose: 0.156 mg/kg
Compound 3: middle estimate off by 64-fold (1.81 log units), on the high side, and the stated range ends above it.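

In this assay, trifluoromethyl in place of methylsulfanyl gives a 64-fold lower number from compound 2 to compound 3 (1.81 log units; beyond the scatter), so the group on this aromatic carbon can move the minimum effective dose far beyond the scatter. Trifluoromethyl in place of methyl gives an at least 32-fold lower number from compound 1 to compound 3 (1.50 log units; beyond the scatter), a size that is only a bound: the limit of > 5 mg/kg in this assay, at which 1 of the 3 values shown sits.

On these data alone, whether a nitrile, an amine or a longer chain on this same carbon would give a number as low as that of compound 3 remains open. So does whether trifluoromethyl keeps this effect at other positions on the shared core.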